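This account rests on a few compounds, and the source may have more. Where it says the series, first, only, none or still open, it means among the compounds named here.

Three compounds have been measured in a functional assay on A-375 cells (Homo sapiens) for antiproliferative activity, read by MTT assay, with a stated time of 24 h, tested at 0.14 ug/mL; on this read-out higher numbers stand for a stronger effect at the one concentration tested and lower numbers for a weaker effect:

compound 1, `Cc1ccc2nc(C(=O)Nc3c(F)cc(-c4cccc(F)c4)cc3F)c(C)c(O)c2c1`: 1.06%
compound 2, `CCc1ccc2nc(C(=O)Nc3c(F)cc(-c4cccc(F)c4)cc3F)c(C)c(O)c2c1`: 1.57%
compound 3, `Cc1c(C(=O)Nc2c(F)cc(-c3cccc(F)c3)cc2F)nc2ccc(OC(F)(F)F)cc2c1O`: 0.06%

All three share the same core and differ only in one group on an aromatic carbon of that core. Compound 3 carries a trifluoromethoxy group there, and its number is the smallest of the three, but the gaps to the other two, a number 1 percentage points lower from compound 1 to compound 3 (within the scatter) and a number 1.5 percentage points lower from compound 2 to compound 3 (within the scatter), are both within the scatter, so the three compounds cannot be told apart on these numbers. All of them show almost no effect at the single concentration tested.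

Compound 4, `Cc1c(C(=O)Nc2c(F)cc(-c3cccc(F)c3)cc2F)nc2ccc(C(F)(F)F)cc2c1O`, has not yet been measured. It differs from compound 3 in one place: trifluoromethyl in place of trifluoromethoxy on an aromatic carbon. For the measured compounds named here, the only steps that bear on this change are the two that already swap the group on this aromatic carbon, a number 1 percentage points lower from compound 1 to compound 3 (within the scatter) and a number 1.5 percentage points lower from compound 2 to compound 3 (within the scatter), and each was within the scatter. A further swap at the same place therefore gives no reason to expect a move beyond the scatter.

The step of a number 0.4 percentage points higher from compound 3 to compound 4 (within the scatter) is expected to stay within the scatter. Compound 4 is estimated to give 0.5%, with a range from -3% to 8%.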

Compound 4, a percentage reported as inhibition, at one concentration (the size of the read-out at that concentration, not a potency): 9.37%
Beside the measured number, compound 4's estimate is 8.9 percentage points below it; the whole stated range lies below it.
By their numbers in this assay, from the lowest: compounds 3, 1, 2 and 4 (each within the scatter of the next).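

Trifluoromethyl is the fourth group placed on this aromatic carbon, and the step of a number 9.3 percentage points higher from compound 3 to compound 4 (within the scatter) is the largest seen at this position, yet it still does not separate the two compounds in this assay. The other two steps to the new compound, a number 7.8 percentage points higher from compound 2 to compound 4 (within the scatter) and a number 8.3 percentage points higher from compound 1 to compound 4 (within the scatter), also stay within the scatter, so methyl, ethyl, trifluoromethoxy and trifluoromethyl cannot be told apart here, and the position has not yet shown a clear response to any swap made at it. Nothing measured here explains the size of these steps.

The compounds shown leave open whether a group of another kind on this aromatic carbon, such as an amine, a carboxylic acid or a longer chain, would produce a step beyond the scatter. They also leave open how the four compounds would compare at other concentrations, and what changes elsewhere on the shared core would do, since everything outside this one position is the same in all four.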